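Methoxy for fluoro on the central ring: rat microsome clearance

This account rests on a few compounds, and the source may have more. Where it says the series, first, only, none or still open, it means among the compounds named here.

Measured so far:
compound 1 `O=S(=O)(CC1CC1)c1nnc(-c2cc(F)c(-c3cnc(Oc4ccccc4C(F)(F)F)c(Cl)c3)cc2F)[nH]1` — < 14 uL/min
compound 2 `CC(C)COc1ncc(-c2ccc(-c3nnc(S(=O)(=O)C4CCC4)[nH]3)cc2F)cc1Cl` — 71 uL/min

Going by the values given here, in an ADME assay on microsomes from liver (Rattus norvegicus) for metabolic stability (on this read-out lower numbers stand for slow clearance and higher numbers for fast clearance), compound 2 gives 71 uL/min, the only outright number in the set. For compound 1 the value < 14 uL/min is a limit of this assay, not a number, and it sits at the limit of < 14 uL/min in this assay, at which 1 of the 2 values shown sits. Compound 3 `COc1cc(-c2nnc(S(=O)(=O)C3CCC3)[nH]2)ccc1-c1cnc(OCC(C)C)c(Cl)c1` differs from compound 2 by methoxy in place of fluoro on an aromatic carbon. Among the compounds with values here, no measured step covers such a change. The expected step is a 1.3-fold higher number from compound 2 to compound 3 (0.10 log units; within the scatter), pointing toward faster clearance but not clearly beyond the usual scatter. Compound 3 is therefore expected at 90 uL/min, with a range of 45 uL/min to 180 uL/min.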

Compound 3, intrinsic clearance in a liver preparation (reported as CLH), per the amount of preparation that the assay uses: 61 uL/min
Beside the measured number, compound 3's estimate is 1.5-fold (0.17 log units) above it, within the range that was stated.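

In this assay, methoxy in place of fluoro on this aromatic carbon, ortho to a large group and meta to a large group, gives a 1.2-fold lower number from compound 2 to compound 3 (0.07 log units; within the scatter). Going by these compounds alone, this is the first measured step at this position, and in this pair the two groups cannot be told apart on this read-out. Nothing in the data at hand gives a reason for this result.

The finding rests on one pair, with one shared set of other groups, so it may not carry over to other members of the series. As far as these compounds go, whether a hydroxyl, an amine or a longer chain such as ethoxy at this carbon would also stay within the scatter remains open.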